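Adding a Methoxycarbonyl Group: What Solubility May Follow

The compounds below may be only part of what the source reports. "The series", "measured", "known", "first", "only" and "open" are said of these compounds alone.

In a physicochemical assay for solubility, with a stated time of 24 h, at pH 6.8 (on this read-out higher numbers stand for higher solubility and lower numbers for lower solubility), compound 2 `CN(C)C(=O)c1ccc2cccccc1-2` gives > 40 ug/mL, which is a limit of the assay rather than a number. Compound 1 `COC(=O)c1ccc2ccc(C(=O)N(C)C)c-2cc1` gives > 64 ug/mL in this assay, again a limit. The change between them, (methoxycarbonyl in place of hydrogen on an aromatic carbon), therefore yields a step that the two limits leave unreadable from compound 2 to compound 1. Compound 3 `CN(C)C(=O)c1cn(C)c2ccccc12` gives > 51 ug/mL in this assay, also a limit. The difference between the core of compound 3 and the core of compound 2 is not broken down here.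

Compound 4 `COC(=O)c1ccc2c(C(=O)N(C)C)cn(C)c2c1` has not yet been measured. Its change from compound 3 is methoxycarbonyl in place of hydrogen on an aromatic carbon. This is the same kind of change as in compound 1, not the same: there the group sat on a seven-membered aromatic ring of carbon only, whereas here it sits on a six-membered aromatic ring of carbon only, meta to a fused ring and para to a fused ring.

The step expected in this assay is an at least 1.0-fold lower number from compound 3 to compound 4 (0.00 log units; that floor lies within the scatter), which rests on the unreadable step that the two limits leave unreadable from compound 2 to compound 1 and on compound 3 sitting at the limit of > 51 ug/mL in this assay, at which 1 of the 3 values shown sits. Compound 4 is estimated to give about 50 ug/mL in this assay, between 15 ug/mL and 150 ug/mL.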

Compound 4, solubility: 49 ug/mL
Beside the measured number, compound 4's estimate is 1.0-fold (0.01 log units) above it, and the stated range covers the measured number.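

In this assay, putting methoxycarbonyl in place of hydrogen on an aromatic carbon of the core of compound 3 gives an at least 1.0-fold lower number from compound 3 to compound 4 (0.01 log units; that floor lies within the scatter). That step is only a floor, and no real fall in the number can be claimed, because the starting point is a limit of the assay and not a number: the limit of > 51 ug/mL in this assay, at which 1 of the 4 values shown sits. The matching step from compound 2 to compound 1 cannot be read, with a limit at both of its ends, so this result gives compound 4 a real number on its core but does not show that the change behaves alike on the two cores.

The compounds shown leave open how far compound 3 truly lies from compound 4, and whether any real gap separates them at all. They also leave open how a carboxylic acid or an amine, set in place of that same hydrogen, would read in this assay.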